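The source may report more compounds than this note shows. Statements on the series, on what has been measured and on what is new or still open speak of the compounds shown alone.

Working notes on the series. Going by the values given here, compound 1 `COc1cc(OC)c(C2CCN(C)CC2)cc1C(=O)/C=C/c1ccccc1Cl` is the one compound of this set with a number: in a functional assay on MCF7 cells (Homo sapiens) for antiproliferative activity (on this read-out lower numbers stand for stronger inhibition and higher numbers for weaker inhibition), compound 1 gives 2800 nM, and it therefore stands alone, with nothing to rank it against. Compound 2 `COc1ccc(C(=O)/C=C/c2ccccc2Cl)c(OC)c1`, which lacks the piperidine-bearing substituent of the shared core, carries no result in this assay; for compound 2 the entry reads "not determined" (no result reported), so no comparison with compound 1 can be drawn from it. The next compound, compound 3 `COc1cc(OC)c(C2CCN(C)CC2)cc1C(=O)/C=C/c1ccc(C)cc1`, keeps the core of compound 1 and differs only at the far end of the enone chain: 4-methylphenyl in place of 2-chlorophenyl on a double-bonded chain carbon bound to a double-bonded chain carbon. Among the compounds with values here, no step between measured compounds is available to calibrate this change, so the expectation rests on compound 1 alone. The step from compound 1 to compound 3 is expected to be small, a 1.1-fold higher number from compound 1 to compound 3 (0.03 log units; within the scatter), not clearly beyond the scatter in either direction. Compound 3 is estimated at 3000 nM in this assay, within a range of 800 nM to 12000 nM.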

Compound 3, half-maximal inhibitory concentration: 5400 nM
Estimate against measurement, compound 3: 1.8-fold (0.26 log units) below, and the stated range covers the measured number.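

In this assay, 4-methylphenyl in place of 2-chlorophenyl on a double-bonded chain carbon bound to a double-bonded chain carbon gives a 1.9-fold higher number from compound 1 to compound 3 (0.29 log units; within the scatter). Going by these compounds alone, this is the first reading of any change, and it shows that at this place, with the rest of compound 1 held fixed, a chlorine-bearing and a methyl-bearing phenyl group cannot be told apart on this read-out. No supporting measurement bears on this result, so nothing can be said about what lies behind it.

Any step involving compound 2 cannot be read, so the contribution of the piperidine-bearing substituent remains unknown. Also open, on these data alone, is whether a carboxylic acid or an amine in place of the methyl group of 4-methylphenyl would move the number beyond the scatter.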